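This account rests on a few compounds, and the source may have more. Where it says the series, first, only, none or still open, it means among the compounds named here.

Compound 1 `O=C(O)CNC(=O)CN(c1nc(Cl)nc2[nH]cnc12)C1CC1`: 9.08%
Compound 2 `O=C(O)CC[C@H](NC(=O)CN(c1nc(Cl)nc2[nH]cnc12)C1CC1)C(=O)O`: 29.5%

In a functional assay on the whole organism (Tail, strain ICR) with Mus musculus as the target, in the tail flick test, with a stated time of 150 min, at a dose of 25 umol/kg by the oral route (on this read-out lower numbers stand for a weaker effect and higher numbers for a stronger effect at the one dose given), compound 2 gives 29.5%, the higher of the two numbers measured; compound 1 gives 9.08%. Among the compounds with values here, the one measured step, a number 20.4 percentage points higher from compound 1 to compound 2 (beyond the scatter), came with 2-carboxyethyl entering. Compound 3 `C[C@@H](O)[C@H](NC(=O)CN(c1nc(Cl)nc2[nH]cnc12)C1CC1)C(=O)O` differs from compound 2 by 1-hydroxyethyl in place of 2-carboxyethyl on a saturated chain carbon bound to an amide-type nitrogen and a carbonyl carbon. The step from compound 1 to compound 2 bears directly on this change, since the 2-carboxyethyl now leaves again, though 1-hydroxyethyl enters in its place rather than hydrogen. Compound 3 is therefore expected to fall partway back toward compound 1, a step of a number 11.5 percentage points lower from compound 2 to compound 3 (beyond the scatter). The estimate for compound 3 is 18%, in the range 6% to 30%.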

Compound 3, a percentage reported as activity, at one dose (the size of the read-out at that dose, not a potency): 24%
Compound 3: middle estimate off by 6 percentage points, on the low side; measured number inside the range.
By their numbers in this assay, from the lowest: compound 1; then compounds 3 and 2 (each within the scatter of the next).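

In this assay, the exchange of 2-carboxyethyl for 1-hydroxyethyl on the saturated chain carbon gives a step of a number 5.5 percentage points lower from compound 2 to compound 3 (within the scatter), so these two groups cannot be told apart here. The gain over hydrogen therefore does not require 2-carboxyethyl, since 1-hydroxyethyl also gives a step of a number 14.9 percentage points higher from compound 1 to compound 3 (beyond the scatter). No evidence is available to explain this result. Going by these compounds, whether a simple methyl, which has no oxygen, or a chain ending in an amine would also raise the number over hydrogen at this carbon remains open.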